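Series notes: replacing the acetylphenyl arm of compound 3

This account rests on a few compounds, and the source may have more. Where it says the series, first, only, none or still open, it means among the compounds named here.

The three measured compounds share one core and differ on one aromatic carbon: compound 1 `COC(=O)/C=C/c1cccc(N(Cc2ccc(C(C)(C)C)cc2)C(=O)C2CCCCC2)c1` carries a tert-butyl there, compound 2 `COC(=O)/C=C/c1ccc(CN(C(=O)C2CCCCC2)c2cccc(/C=C/C(=O)OC)c2)cc1` a 2-(methoxycarbonyl)ethenyl, and compound 3 `COC(=O)/C=C/c1cccc(N(Cc2ccc(-c3cccc(C(C)=O)c3)cc2)C(=O)C2CCCCC2)c1` a 3-acetylphenyl. In an assay on isolated protein with Bile acid receptor (Homo sapiens) as the target (a higher number here means that more compound is needed for the effect, a lower number that less compound is needed), compound 1 gives only a limit, > 1000 nM. Compound 2 likewise gives only a limit, > 1000 nM. Within the data shown here, compound 3 gives 227 nM, the only real number among the three; the other two sit at the limit of > 1000 nM in this assay, at which 2 of the 3 values shown sit. The step that the two limits leave unreadable from compound 1 to compound 2 cannot be read. The steps of an at least 4.4-fold lower number from compound 1 to compound 3 (0.64 log units; beyond the scatter) and an at least 4.4-fold lower number from compound 2 to compound 3 (0.64 log units; beyond the scatter) show that the 3-acetylphenyl arm yields a measurable number where the smaller groups did not.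

Compound 4 `COC(=O)/C=C/c1cccc(N(Cc2ccc(/C=C/c3cccc(Cl)c3)cc2)C(=O)C2CCCCC2)c1` differs from compound 3 by 2-(3-chlorophenyl)ethenyl in place of 3-acetylphenyl on an aromatic carbon. Among the measured compounds shown here, the two readable steps bear on it only indirectly: they show that an arm of this size on that carbon gives a number, but no measured pair exchanges one such arm for another, so the direction of the step is open. The arm keeps its size; the single acceptor is lost. A number of the same order as that of compound 3 is expected. For compound 4 the estimate is 450 nM, between 120 nM and 1800 nM, which means an expected step of a 2.0-fold higher number from compound 3 to compound 4 (0.30 log units; within the scatter).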

Compound 4, half-maximal effective concentration: 165 nM
Compound 4: the middle estimate sits 2.7-fold (0.44 log units) above what was measured; measured number inside the range.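

In this assay, among these compounds, the exchange of one arm for another with the same heavy-atom count gives a 1.4-fold lower number from compound 3 to compound 4 (0.14 log units; within the scatter), the first such exchange, at this aromatic carbon para to a large group. With the hydrogen-bond acceptor of 3-acetylphenyl gone, 2-(3-chlorophenyl)ethenyl still gives a real number, so a measurable value at this carbon does not depend on that acceptor in this pair, and the series now holds a second arm that gets past the assay limit, as an at least 6.0-fold lower number from compound 1 to compound 4 (0.78 log units; beyond the scatter) and an at least 6.0-fold lower number from compound 2 to compound 4 (0.78 log units; beyond the scatter) show for the tert-butyl and 2-(methoxycarbonyl)ethenyl compounds. Both of these last steps start from a limit and not from a number, for compound 1 and for compound 2 alike, so their full size stays unread: the limit of > 1000 nM in this assay, at which 2 of the 4 values shown sit.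

Which part of the new arm carries the value remains open, as no pair here separates the chlorine from the ethenyl link or from the ring itself. As far as these compounds go, how an unsubstituted phenyl, or an arm ending in an amine or a carboxylic acid, would read in this assay is equally open.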